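This account rests on a few compounds, and the source may have more. Where it says the series, first, only, none or still open, it means among the compounds named here.

Measured compounds in a functional assay on HeLa cells (Homo sapiens) for cytotoxicity, read by MTT assay, with a stated time of 48 h; a higher number here means a weaker inhibitor, a lower number a stronger inhibitor:

compound 1 `CCOC(=O)c1c(-c2cc3ccccc3oc2=O)nn(-c2cccc(Cl)c2)c1C(=O)OCC` gives 22000 nM
compound 2 `COC(=O)c1c(-c2cc3ccccc3oc2=O)nn(-c2cccc(Cl)c2)c1C(=O)OC` gives 76000 nM
compound 3 `CCOC(=O)c1c(-c2cc3ccccc3oc2=O)nn(-c2cccc(F)c2)c1C(=O)OCC` gives 68000 nM

The three share a core and differ at two places: the ester groups and the halogen on the phenyl ring. How compound 2 differs from compound 1 is not broken down here; the two values show compound 2 at the higher number, and in this assay compound 2 stands highest of the three, with compound 3 near it and compound 1 furthest away. Within the data shown here, the one pair that differs in a single place is compound 1 to compound 3: the change is fluoro in place of chloro on an aromatic carbon and it gave a 3.1-fold higher number from compound 1 to compound 3 (0.49 log units; beyond the scatter).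

Compound 4 `COC(=O)c1c(-c2cc3ccccc3oc2=O)nn(-c2cccc(F)c2)c1C(=O)OC` has not yet been measured. Among the measured compounds shown here, it is reached from compound 2 by fluoro in place of chloro on an aromatic carbon, which is the same change as the one from compound 1 to compound 3, at the same place on the ring. For the measured compounds named here, only one earlier instance of this change is available, so the expectation rests on it alone. From compound 2 to compound 4 the step is expected to be a 2.6-fold higher number from compound 2 to compound 4 (0.42 log units; beyond the scatter), close in size to the step seen from compound 1 to compound 3, because that step was a 3.1-fold higher number from compound 1 to compound 3 (0.49 log units; beyond the scatter). Compound 4 is therefore estimated at 200000 nM, with a plausible range from 70000 nM to 500000 nM; since compound 2 already sits at the high end of the series, the assay may report only a limit rather than a number.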

Compound 4, half-maximal inhibitory concentration: 76000 nM
The estimate for compound 4 lay 2.6-fold (0.42 log units) above the measured number; the range from low to high includes it.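

In this assay, fluoro in place of chloro on the methyl ester core gave no change at the digits printed from compound 2 to compound 4 (within the scatter), so the swap left no readable mark on this core. The same 3-chlorophenyl to 3-fluorophenyl change therefore did not carry over at one size from the ethyl ester core to the methyl ester core: the same change on two cores in this assay, a 3.1-fold higher number (0.49 log units; beyond the scatter) from compound 1 to compound 3 and no change at the digits printed (within the scatter) from compound 2 to compound 4, 3.1-fold (0.49 log units) apart, beyond the scatter of two such steps This shows that, in these two pairs, the size of the step depends on the core it is made on, so a step read on one core is a poor guide to the other; it does not show why the two steps differ, and two instances give no rule for any further core.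

The compounds shown hold only chloro and fluoro on the phenyl ring and only methyl and ethyl esters on the shared core, so it remains open whether the dependence on the core extends to a bromo, methoxy or trifluoromethyl group at that place. Also open, from the compounds shown here alone, is how the halogen swap would read with a longer ester chain such as butyl, or with a carboxylic acid or an amide in place of the esters.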